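The source may hold more compounds than are shown below. What is called first, only, known or untested is meant among the compounds shown, and "the series" means these compounds.

Compound 1 `Cc1n[nH]c(C)c1Oc1c(O)cc(O)c2c(=O)cc(-c3ccc(N4CCN(c5ccccn5)CC4)cc3)oc12` gives 1200 nM in an assay on cells for inhibition of ubiquitin carboxyl-terminal hydrolase 8 (Homo sapiens), read by fluorescence, with a stated time of 30 min; on this read-out higher numbers stand for weaker inhibition and lower numbers for stronger inhibition.
Compound 2 `CCN1CCN(c2ccc(-c3cc(=O)c4c(O)cc(O)c(Oc5c(C)n[nH]c5C)c4o3)cc2)CC1` gives 15500 nM in this assay.

Compound 2 stands at the weaker end of the two numbers measured, its nearest neighbour being compound 1, and the step of a 13-fold higher number from compound 1 to compound 2 (1.11 log units; beyond the scatter) lies beyond the scatter. Compound 3 `Cc1n[nH]c(C)c1Oc1c(O)cc(O)c2c(=O)cc(-c3ccc(N4CCN(C(=O)c5ccco5)CC4)cc3)oc12` is not yet measured. It differs from compound 2 in one place: (furan-2-yl)carbonyl in place of ethyl on an amine nitrogen in a ring. Among the compounds with values here, the only measured step that bears on this change is the one from compound 1 to compound 2, where a ring group on the same amine nitrogen was exchanged for ethyl, and the number rose by a 13-fold higher number from compound 1 to compound 2 (1.11 log units; beyond the scatter). Compound 3 reverses that direction, putting a ring-bearing group back in place of ethyl, though the group now carries a carbonyl and a different ring. Compound 3 is therefore expected to show a lower number than compound 2, a step of about a 5.2-fold lower number from compound 2 to compound 3 (0.71 log units; beyond the scatter), smaller than the measured step. The estimate for compound 3 is 3000 nM, with a range from 900 nM to 10000 nM.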

Compound 3, half-maximal inhibitory concentration: 5100 nM
Compound 3: the middle estimate sits 1.7-fold (0.23 log units) below what was measured; measured number inside the range.
By their numbers in this assay, from the lowest: compound 1; then compound 3; then compound 2.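

On the amine nitrogen of the six-membered ring, (furan-2-yl)carbonyl gives a third level in this assay: it recovers part of what ethyl lost (a 3.0-fold lower number from compound 2 to compound 3 (0.48 log units; beyond the scatter)) but does not reach pyridin-2-yl (a 4.3-fold higher number from compound 1 to compound 3 (0.63 log units; beyond the scatter)). An aromatic ring in the group is therefore not enough to set the number, as the two groups that each carry one stand apart by a step beyond the scatter. Nothing available here accounts for the order of the three groups.

The compounds shown do not separate the carbonyl from the furan ring in this change, which a plain acetyl or a furan-2-yl directly on the same nitrogen could address. They also leave open how a phenyl or a pyrimidin-2-yl at this nitrogen would read.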